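Amide variation in a weakly active antiproliferative series

The compounds below may be only part of what the source reports. "The series", "measured", "known", "first", "only" and "open" are said of these compounds alone.

Compound 1 `Cc1cc(Cl)ccc1C(=O)Nc1ccc(Cl)c(-c2nnc3c(Cl)cccn23)c1`, compound 2 `O=C(Nc1ccc(Cl)c(-c2nnc3c(Cl)cccn23)c1)c1ccon1`.

In a functional assay on MCF7 cells (Homo sapiens) for antiproliferative activity, read by MTT assay, with a stated time of 72 h (on this read-out higher numbers stand for weaker inhibition and lower numbers for stronger inhibition), compound 1 gives > 100000 nM, which is a limit of the assay and not a number. Compound 2 gives > 100000 nM in this assay, again a limit rather than a number. The step that the two limits leave unreadable from compound 1 to compound 2 is therefore unreadable in size and direction. Within the data shown here, every value so far sits at the limit of > 100000 nM in this assay, at which 2 of the 2 values shown sit, so compound 2 stands at the limit itself, with no measured potency to build on.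

Compound 3 `CS(=O)(=O)c1cccc(C(=O)Nc2ccc(Cl)c(-c3nnc4c(Cl)cccn34)c2)c1` carries the change (3-(methylsulfonyl)phenyl in place of 1,2-oxazol-3-yl on a carbonyl carbon). Among the measured compounds shown here, no measured step bears on this change in a readable way: the only step available is a step that the two limits leave unreadable from compound 1 to compound 2, which the two limits leave without a size. With both amide variants at the limit, compound 3 is expected to stay there as well, and no step beyond the scatter is expected, a number no higher from compound 2 to compound 3 (the limit leaves the size open). Compound 3 is estimated at 100000 nM in this assay, with a range of 30000 nM to 300000 nM, and most likely the assay will again report only a limit.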

Compound 3, half-maximal inhibitory concentration: 88900 nM
Estimate against measurement, compound 3: 1.1-fold (0.05 log units) above, within the range that was stated.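

With 3-(methylsulfonyl)phenyl on the carbonyl carbon, compound 3 is the only amide shown that returns a number in this assay, which gives the series its first readable value at this position. On these data alone, the change reads as an at least 1.1-fold lower number from compound 2 to compound 3 (0.05 log units; that floor lies within the scatter) and as an at least 1.1-fold lower number from compound 1 to compound 3 (0.05 log units; that floor lies within the scatter); each is only a floor, so the true size stays open and these data support no claim of a real gain in potency. Compound 1 and compound 2 each stay at a limit of the assay and not at a number, so the step between them cannot be read: the limit of > 100000 nM in this assay, at which 2 of the 3 values shown sit.

Still open is whether the methylsulfonyl group itself matters, since no unsubstituted phenyl amide is among the compounds shown to set against compound 3. Also open, as far as these compounds go, is whether a primary amine or a carboxylic acid in place of the methylsulfonyl group on the same phenyl ring would bring the number clearly beyond the scatter from compound 3 in this assay.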